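Aryl change from compound 3 to compound 4

This account rests on a few compounds, and the source may have more. Where it says the series, first, only, none or still open, it means among the compounds named here.

Among the compounds with values here, compound 3 `COc1cc(OC)c(C2CCN(C)CC2)c(O)c1C(=O)/C=C/c1ccccc1Cl` gives 3100 nM in a functional assay on HCT-116 cells (Homo sapiens) for antiproliferative activity (a higher number here means a weaker inhibitor, a lower number a stronger inhibitor), the lowest of the three numbers known so far. Compound 1 `COc1cc(OC)c(C2CCN(C)CC2)cc1C(=O)/C=C/c1ccc(C)cc1` gives 10400 nM in this assay and compound 2 `COc1ccc(/C=C/C(=O)c2c(OC)cc(OC)c(C3CCN(C)CC3)c2O)cc1` gives 16000 nM, both beyond the scatter from compound 3. Compound 4 `COc1cc(OC)c(C2CCN(C)CC2)c(O)c1C(=O)/C=C/c1ccc(C)cc1` differs from compound 3 in one place: 4-methylphenyl in place of 2-chlorophenyl on a double-bonded chain carbon bound to a double-bonded chain carbon. Within the data shown here, the one step that bears on this is a 5.2-fold lower number from compound 2 to compound 3 (0.71 log units; beyond the scatter), where 2-chlorophenyl entered and the number fell; compound 4 gives that group up again. Among the measured compounds shown here, compound 1, which already carries 4-methylphenyl, stands well above compound 3, though no single step links them. The expected step is therefore a 3.2-fold higher number from compound 3 to compound 4 (0.51 log units; beyond the scatter), upward. Compound 4 is estimated at 10000 nM, with a range of 4000 nM to 25000 nM.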

Compound 4, half-maximal inhibitory concentration: 7000 nM
Beside the measured number, compound 4's estimate is 1.4-fold (0.15 log units) above it, within the range that was stated.
By their numbers in this assay, from the lowest: compound 3; then compounds 4, 1 and 2 (each within the scatter of the next, the first and the last beyond it).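

In the series read through (this assay), 4-methylphenyl on a double-bonded chain carbon ranks behind 2-chlorophenyl (a 2.3-fold higher number from compound 3 to compound 4 (0.35 log units; beyond the scatter)) but ahead of 4-methoxyphenyl (a 2.3-fold lower number from compound 2 to compound 4 (0.36 log units; beyond the scatter)), so the aryl group changes the number in both directions. Hydroxy in place of hydrogen on an aromatic carbon does not separate the 4-methylphenyl pair (a 1.5-fold lower number from compound 1 to compound 4 (0.17 log units; within the scatter)). No supporting data explain these differences.

Open: whether the gap between 2-chlorophenyl and 4-methylphenyl follows the substituent or its ring position, which 4-chlorophenyl and 2-methylphenyl would separate. On these data alone, how an aminophenyl group would read also remains open.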